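Oxazole amide replacement and its expected effect on FAAH inhibition

The source may report more compounds than this note shows. Statements on the series, on what has been measured and on what is new or still open speak of the compounds shown alone.

Of the compounds shown here, two that share a core have been measured in an assay for inhibition of Fatty-acid amide hydrolase 1 (Rattus norvegicus); a lower number here means a stronger inhibitor, a higher number a weaker inhibitor. Compound 1 `CN(C)C(=O)c1cnc(C(=O)CCc2ccc(Oc3ccccc3)cc2)o1` gives 5.4 nM. Going by the values given here, compound 2 `COC(=O)c1ccc(-c2cnc(C(=O)CCc3ccc(Oc4ccccc4)cc3)o2)nc1` gives 54 nM, which is the higher of the two numbers; the only measured step, a 10-fold higher number from compound 1 to compound 2 (1.00 log units; beyond the scatter), lies beyond the scatter. Compound 3 `CNC(=O)c1cnc(C(=O)CCc2ccc(Oc3ccccc3)cc2)o1` has not yet been measured. It differs from compound 2 in one place: methylcarbamoyl in place of 5-(methoxycarbonyl)pyridin-2-yl on an aromatic carbon. The step from compound 1 to compound 2 bears directly on this change, since it removes the same dimethylcarbamoyl group that compound 3 restores in a closely related form, and it was a modest worsening of a 10-fold higher number from compound 1 to compound 2 (1.00 log units; beyond the scatter). Compound 3 is therefore expected to move back toward compound 1, with an improvement of about a 6.8-fold lower number from compound 2 to compound 3 (0.83 log units; beyond the scatter) in this assay, because compound 1 gives 5.4 nM with a group that differs from methylcarbamoyl only in one methyl. On that basis compound 3 is estimated at 8 nM, in a range from 2.5 nM to 25 nM.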

Compound 3, inhibition constant: 11 nM
The estimate for compound 3 lay 1.4-fold (0.14 log units) below the measured number; measured number inside the range.
By their numbers in this assay, from the lowest: compound 1; then compound 3; then compound 2.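

At the aromatic carbon next to the ring oxygen, methylcarbamoyl recovers most of the rise seen with 5-(methoxycarbonyl)pyridin-2-yl, giving a 4.9-fold lower number from compound 2 to compound 3 (0.69 log units; beyond the scatter) in this assay and showing that this position does not need the larger group with its six-membered aromatic ring to keep a low number. The amide nitrogen now has a reading of its own: hydrogen in place of methyl gives a 2.0-fold higher number from compound 1 to compound 3 (0.31 log units; beyond the scatter) and, although this step is small, it is printed as beyond the scatter, so the amide hydrogen of compound 3 brings no lower number than the second methyl of compound 1. No measurement is available to explain either step.

The compounds shown leave open how far the amide nitrogen tolerates change, for example with an unsubstituted carboxamide, a diethylamide or a pyrrolidine amide. They also leave open whether the higher number of compound 2 follows from the pyridine ring itself or from its methyl ester, which a carboxylic acid or a plain pyridin-2-yl group at the same place would help to separate.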